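From Chloro to Bromo: Expected Cytotoxicity of Compound 4

The source may report more compounds than this note shows. Statements on the series, on what has been measured and on what is new or still open speak of the compounds shown alone.

Compound 1 `COc1ccc(C(=O)N/N=C/c2cc(I)c(O)c(I)c2)cc1`: in a functional assay on HepG2 cells (Homo sapiens) for cytotoxicity, with a stated time of 24 h (a lower number here means a stronger inhibitor, a higher number a weaker inhibitor), compound 1 gives > 100000 nM, a limit of the assay rather than a number.
Compound 2 `CC(C)(C)c1ccc(C(=O)N/N=C/c2cc(I)c(O)c(I)c2)cc1`: compound 2 gives 45900 nM.
Compound 3 `O=C(N/N=C/c1cc(I)c(O)c(I)c1)c1ccc(Cl)cc1`: compound 3 gives > 100000 nM, again a limit.

Compound 3 therefore sits at the limit of > 100000 nM in this assay, at which 2 of the 3 values shown sit. Compound 4 `O=C(N/N=C/c1cc(I)c(O)c(I)c1)c1ccc(Br)cc1` differs from it by bromo in place of chloro on an aromatic carbon. Within the data shown here, two measured steps touch compound 3: an at least 2.1-fold higher number from compound 2 to compound 3 (0.33 log units; beyond the scatter), and a step that the two limits leave unreadable from compound 1 to compound 3. Among the measured compounds shown here, no measured step exchanges one halogen for another, so the nearest guide is the weak showing of compound 3 itself. The expectation is a number no higher from compound 3 to compound 4 (the limit leaves the size open), most likely a limit once more. Compound 4 is estimated at 100000 nM, with a range from 40000 nM to 300000 nM.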

Compound 4, half-maximal inhibitory concentration: > 50000 nM
Compound 4: no number, only a limit (the forecaster's own chance of this, stated with the estimate: 70%); the middle value lies beyond the limit too.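

Compound 4, like compound 3, ends at a limit of the assay and not at a number: the limit of > 50000 nM in this assay, at which 1 of the 4 values shown sits. On these data alone, the steps from compound 4 to compound 1 and to compound 3 cannot be read, so the size of the change from chloro to bromo stays unknown. Among these compounds, the one readable step is an at least 1.0-fold higher number from compound 2 to compound 4 (0.03 log units; that floor lies within the scatter), so bromo, unlike chloro, cannot yet be set clearly apart from tert-butyl.

Among the compounds shown, only compound 2 gives a number. As far as these compounds go, how an amine or a carboxylic acid at this position would read in this assay remains open.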